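From isopropyl to butyl on the aromatic ring

A few compounds are considered here, and "the series" means these few. Any claim that something is new, unique, unknown or untested is made for them only; others in the source may bear on it.

Compound 2 `CC(C)c1ccc(C(=O)CC(SCC(=O)O)C(=O)O)cc1` gives 3330 nM in a functional assay on HeLa cells (Homo sapiens) (a lower number here means a stronger inhibitor, a higher number a weaker inhibitor), the low end of the two numbers in hand. Compound 1 `CCc1ccc(C(=O)CC(SCC(=O)O)C(=O)O)cc1` gives 4790 nM in this assay. The step of a 1.4-fold lower number from compound 1 to compound 2 (0.16 log units; within the scatter) is the only one measured, and it enlarged the alkyl group without leaving the scatter. Compound 3 `CCCCc1ccc(C(=O)CC(SCC(=O)O)C(=O)O)cc1` differs by butyl in place of isopropyl on an aromatic carbon. Since that one step stayed within the scatter, no step beyond the scatter is expected for compound 3 in this assay. Compound 3 is therefore estimated at 3000 nM, with a range of 1300 nM to 7000 nM, an expected step of a 1.1-fold lower number from compound 2 to compound 3 (0.05 log units; within the scatter).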

Compound 3, half-maximal inhibitory concentration: 1910 nM
Beside the measured number, compound 3's estimate is 1.6-fold (0.20 log units) above it; low and high end bracket the measured number.
By their numbers in this assay, from the lowest: compounds 3, 2 and 1 (each within the scatter of the next, the first and the last beyond it).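

Within the data shown here, on the aromatic carbon, a 1.7-fold lower number from compound 2 to compound 3 (0.24 log units; within the scatter) stays within the scatter, but butyl gives the first step on this alkyl group to leave it: in this assay, a 2.5-fold lower number from compound 1 to compound 3 (0.40 log units; beyond the scatter) is a modest one. Ethyl and butyl can therefore be told apart here, which ethyl and isopropyl could not. No evidence is at hand that bears on this result. Going by these compounds, whether a longer chain such as hexyl would extend the step stays open, as does what an amine or a phenyl group would give on this carbon.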